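A hydroxymethyl-to-carboxy swap and expected monkey exposure

The compounds below may be only part of what the source reports. "The series", "measured", "known", "first", "only" and "open" are said of these compounds alone.

Measured compounds:
- compound 1, `CCCCN(c1nc2c(CO)cccc2o1)[C@H](C)c1ccc(-c2ccccc2-c2nnn[nH]2)cc1`: 20.7 nM
- compound 2, `CCCCN(c1nc2c(C(=O)O)cccc2o1)[C@H](C)c1ccc(-c2cc(Cl)ccc2-c2nc(=O)o[nH]2)cc1`: 677 nM
- compound 3, `CCCCN(c1nc2c(C(=O)N(C)C)cccc2o1)[C@H](C)c1ccc(-c2ccccc2-c2nnn[nH]2)cc1`: 54 nM

In an ADME assay on the whole organism (Macaca fascicularis) for pharmacokinetics, read by LC-MS, using cassette dosing, at a dose of 1 mg/kg by the oral route (on this read-out higher numbers stand for higher exposure at the dose given and lower numbers for lower exposure), compound 1 gives the lowest of the three numbers. Compound 4, `CCCCN(c1nc2c(C(=O)O)cccc2o1)[C@H](C)c1ccc(-c2ccccc2-c2nnn[nH]2)cc1`, is compound 1 with a single change: carboxy in place of hydroxymethyl on an aromatic carbon. Among the compounds with values here, only one measured step touches the same spot: a 2.6-fold higher number from compound 1 to compound 3 (0.42 log units; beyond the scatter). Compound 2 also carries carboxy, and gives the highest number, yet it differs from compound 1 in two further places, so its value cannot be credited to carboxy alone. On the strength of the step from compound 1 to compound 3, a modest rise is expected for compound 4, as a 2.9-fold higher number from compound 1 to compound 4 (0.46 log units; beyond the scatter). Compound 4 is therefore estimated at 60 nM, within the range 20 nM to 200 nM.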

Compound 4, maximal plasma concentration: 238 nM
Compound 4: middle estimate off by 4.0-fold (0.60 log units), on the low side; the measured number lies above the stated range.
By their numbers in this assay, from the lowest: compound 1; then compound 3; then compound 4; then compound 2.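

The group on this aromatic carbon can shift the number much further than the earlier step suggested: carboxy in place of hydroxymethyl brings an 11-fold higher number from compound 1 to compound 4 (1.06 log units; beyond the scatter). Changing only what sits on the carbonyl carbon matters too, with hydroxy in place of dimethylamino bringing a 4.4-fold higher number from compound 3 to compound 4 (0.64 log units; beyond the scatter). No available measurement explains these rises.

As far as these compounds go, whether an amine or a methyl ester at this place would give a number nearer compound 4 or compound 1 remains open. Also open, from the compounds shown here alone, is whether carboxy would bring a similar rise with other groups elsewhere on the core.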